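Sulfonamide Series: Dimethylsulfamoyl Variant of Compound 3

The compounds below may be only part of what the source reports. "The series", "measured", "known", "first", "only" and "open" are said of these compounds alone.

Three compounds share a core carrying a nitro group, a sulfamoyl group and a chain on the ring nitrogen. In an assay on HEK293 cells for inhibition of solute carrier family 12 member 2 (Homo sapiens), read by fluorescence, with a stated time of 30 min, tested at 100 uM (a higher number here means a stronger effect of the compound at the concentration tested, a lower number a weaker effect), compound 1 `CCCCCCNc1ccc([N+](=O)[O-])cc1S(N)(=O)=O` gives 3.8%, compound 2 `CCCCCCCCNc1ccc([N+](=O)[O-])cc1S(N)(=O)=O` gives 5.8% and compound 3 `CC(C)(C)CCNc1ccc([N+](=O)[O-])cc1S(N)(=O)=O` gives 14.5%. Compound 3 has the highest number of the three; the step of a number 10.7 percentage points higher from compound 1 to compound 3 (beyond the scatter) is beyond the scatter, while a number 8.7 percentage points higher from compound 2 to compound 3 (within the scatter) and a number 2 percentage points higher from compound 1 to compound 2 (within the scatter) are not.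

Compound 4 `CN(C)S(=O)(=O)c1cc([N+](=O)[O-])ccc1NCCC(C)(C)C` differs from compound 3 at the sulfonyl sulfur: dimethylamino in place of amino on a sulfonyl sulfur. Within the data shown here, every measured step so far alters the chain on the ring nitrogen; none touches the sulfamoyl group, so no measured step bears on this change, and the chain of compound 3 is kept unchanged. With nothing in the data speaking for a shift, the expectation is no step beyond the scatter, a number 2.5 percentage points lower from compound 3 to compound 4 (within the scatter) being the estimated step. Compound 4 is therefore expected to give about 12% in this assay, within a range of 0% to 28%.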

Compound 4, a percentage reported as inhibition, at one concentration (the size of the read-out at that concentration, not a potency): 17%
Beside the measured number, compound 4's estimate is 5 percentage points below it; the range from low to high includes it.
By their numbers in this assay, from the lowest: compounds 1, 2, 3 and 4 (each within the scatter of the next, the first and the last beyond it).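

Among these compounds, this is the first step at the sulfonyl sulfur: in this assay, dimethylamino in place of amino gives a number 2.5 percentage points higher from compound 3 to compound 4 (within the scatter) and so leaves the read-out unmoved beyond the scatter. The position therefore tolerates the added bulk of 3 heavy atoms in place of 1, and the change from 1 hydrogen-bond donor to 0, at least with the chain of compound 3 in place. No evidence is available to explain this outcome.

On these data alone, whether the same tolerance holds with the hexylamino or octylamino chains of compound 1 and compound 2 remains open. Also open, as far as these compounds go, is how the read-out responds to a larger replacement on the sulfonyl sulfur, such as a morpholine or a carboxylic acid chain, and whether any such change would lift it well clear of the scatter.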